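The source may hold more compounds than are shown below. What is called first, only, known or untested is meant among the compounds shown, and "the series" means these compounds.

Compound 1 `Cn1c(-c2cccc(C#N)c2)cnc1NC(=O)c1ccc(F)cc1` was tested in a toxicity assay on THP-1 cells (Homo sapiens) for inhibition; on this read-out higher numbers stand for lower toxicity in this test and lower numbers for higher toxicity in this test. In this assay compound 1 gives > 100000 nM, which is a limit of the assay rather than a measured number. Compound 2 `Cn1c(-c2cccc(C#N)c2)cnc1NC(=O)c1ncc[nH]1` carries a 1H-imidazol-2-yl in place of 4-fluorophenyl on a carbonyl carbon. In this assay compound 2 gives > 50000 nM, again only a limit. The step that the two limits leave unreadable from compound 1 to compound 2 therefore cannot be read. Compound 3 `COc1ccc(-c2cnc(NC(=O)c3ccccc3OC)n2C)cc1` gives > 100000 nM in this assay, also a limit. Going by the values given here, compound 1 thus stands where every value so far stands, at a limit with no number behind it: two values sit at the limit of > 100000 nM in this assay, at which 2 of the 3 values shown sit, and one at the limit of > 50000 nM in this assay, at which 1 of the 3 values shown sits.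

Compound 4 `Cn1c(-c2ccc(F)cc2)cnc1NC(=O)c1ccc(F)cc1` differs from compound 1 in one place: 4-fluorophenyl in place of 3-cyanophenyl on an aromatic carbon. Among the compounds with values here, no measured step touches this position, and the one step that exists is unreadable, so no size or direction beyond the scatter can be expected.

Compound 4 is therefore expected to give about 150000 nM, within 50000 nM to 500000 nM. The expected step is a step that the limit leaves unreadable from compound 1 to compound 4, most likely again only a limit.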

Compound 4, half-maximal cytotoxic concentration: > 100000 nM
Compound 4: no number, only a limit; the forecaster's own chance of this, stated with the estimate: 85%; the middle value is on the limit's open side.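

The step between compound 1 and compound 4 cannot be read, since each of the two compounds gives only a limit. The compounds shown leave open whether any of them reaches a measurable value in this assay, and whether changing either group alters toxicity at all.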